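The compounds below may be only part of what the source reports. "The series", "measured", "known", "first", "only" and "open" are said of these compounds alone.

Three compounds share one core and differ only in the group on the nitrogen on an aromatic ring. Compound 1 `COc1cc2ncnc(Nc3ccc(F)c(Cl)c3)c2cc1OCCCSc1nc2ccccc2s1` gives 5370 nM in a functional assay on MCF7 cells (Homo sapiens) for cytotoxicity, read by MTT assay, with a stated time of 24 h; on this read-out higher numbers stand for weaker inhibition and lower numbers for stronger inhibition. Compound 2 `COc1cc2ncnc(Nc3cccc(C(F)(F)F)c3)c2cc1OCCCSc1nc2ccccc2s1` gives 4050 nM, and compound 3 `COc1cc2ncnc(Nc3ccc(C)cc3)c2cc1OCCCSc1nc2ccccc2s1` gives 14300 nM. Compound 2 stands at the lowest number of the three, yet its nearest neighbour is compound 1, and the step of a 1.3-fold lower number from compound 1 to compound 2 (0.12 log units; within the scatter) lies within the scatter, so no order between the two can be read. The two larger steps, a 2.7-fold higher number from compound 1 to compound 3 (0.43 log units; beyond the scatter) and a 3.5-fold higher number from compound 2 to compound 3 (0.55 log units; beyond the scatter), lie beyond the scatter and are modest in size.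

Compound 4 `CCCCc1nc(Cl)c(C=O)n1CCCOc1cc2c(Nc3cccc(C(F)(F)F)c3)ncnc2cc1OC` keeps the group of compound 2 on the nitrogen and changes the end of the chain: 2-butyl-4-chloro-5-formyl-1H-imidazol-1-yl in place of (1,3-benzothiazol-2-yl)sulfanyl on a saturated chain carbon, three bonds along the chain from an oxygen on an aromatic ring. None of the three measured steps touches that place; each of them varies the group on the nitrogen alone. Among the compounds with values here, no measured step therefore bears on this change, and the data give neither a size nor a direction for it. For compound 4 the expected step is a 1.2-fold higher number from compound 2 to compound 4 (0.09 log units; within the scatter), set near no change, with a wide range that reflects the untested ground. In this assay compound 4 is estimated at 5000 nM, between 1200 nM and 25000 nM.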

Compound 4, half-maximal inhibitory concentration: 3510 nM
Compound 4: the middle estimate sits 1.4-fold (0.15 log units) above what was measured; low and high end bracket the measured number.
By their numbers in this assay, from the lowest: compounds 4, 2 and 1 (each within the scatter of the next); then compound 3.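

In this assay, within the data shown here, the end of the chain is varied for the first time, and 2-butyl-4-chloro-5-formyl-1H-imidazol-1-yl in place of (1,3-benzothiazol-2-yl)sulfanyl gives a 1.2-fold lower number from compound 2 to compound 4 (0.06 log units; within the scatter) and so no order between the two compounds can be read. The earlier compounds shown here varied only the group on the nitrogen, whereas this pair shows that the number stays within the scatter at this place, on a saturated chain carbon, three bonds along the chain from an oxygen on an aromatic ring, even though the six-membered aromatic ring of carbon only and the sulfur leave and a chlorine and a double bond outside aromatic rings enter. No measured evidence accounts for this result.

Among these compounds, the pair covers only two end groups, both with 3-(trifluoromethyl)phenyl on the nitrogen, so it stays open whether the same holds with 3-chloro-4-fluorophenyl or 4-methylphenyl there. Also open, as far as these compounds go, is what an amine or a carboxylic acid at the end of the chain, or a longer chain, would give in this assay for this series.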